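The compounds below may be only part of what the source reports. "The series", "measured", "known", "first", "only" and "open" are said of these compounds alone.

In a functional assay on HCT-116 cells (Homo sapiens) for antiproliferative activity, read by sulforhodamine B assay, with a stated time of 72 h (on this read-out higher numbers stand for weaker inhibition and lower numbers for stronger inhibition), compound 1 (`Cn1ncc(Cl)c1-c1cc(C(=O)N[C@@H]2CN[C@H](CC(N)=O)C[C@H]2c2ccc(Cl)c(Cl)c2)oc1Cl`) gives 650 nM and compound 2 (`Cn1ncc(Cl)c1-c1cc(C(=O)N[C@@H]2CN[C@H](CCO)C[C@H]2c2ccc(Cl)c(Cl)c2)oc1Cl`) gives 340 nM, so the two values stand within the scatter of each other. Still to be measured is compound 3 (`Cn1ncc(Cl)c1-c1cc(C(=O)N[C@@H]2CN[C@H](CCN3CCCC3)C[C@H]2c2ccc(Cl)c(Cl)c2)oc1Cl`), with the change (pyrrolidin-1-yl in place of hydroxy on a saturated chain carbon, two bonds along the chain from a saturated ring carbon). Among the compounds with values here, only one measured step bears on this chain: a 1.9-fold lower number from compound 1 to compound 2 (0.28 log units; within the scatter), with hydroxymethyl in place of carbamoyl on a saturated chain carbon bound to a saturated ring carbon. Within the data shown here, that is a different exchange, and the series holds no measured example with a ring on this chain, so it offers only weak guidance. No step beyond the scatter is expected in this assay, in either direction, though the uncertainty is wide. The expected step is a 1.1-fold lower number from compound 2 to compound 3 (0.05 log units; within the scatter). For compound 3 the estimated value is 300 nM, with an expected range of 110 nM to 850 nM.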

Compound 3, half-maximal inhibitory concentration: 1940 nM
Beside the measured number, compound 3's estimate is 6.5-fold (0.81 log units) below it; measured number outside the range, above it.
By their numbers in this assay, from the lowest: compounds 2 and 1 (each within the scatter of the next); then compound 3.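

In this assay, within the data shown here, this chain position now shows a change beyond the scatter for the first time: pyrrolidin-1-yl in place of hydroxy gives a 5.7-fold higher number from compound 2 to compound 3 (0.76 log units; beyond the scatter), and (pyrrolidin-1-yl)methyl in place of carbamoyl gives a 3.0-fold higher number from compound 1 to compound 3 (0.47 log units; beyond the scatter). The chain ends of compound 1 and compound 2 stand within the scatter of each other, so among these three only the 2-(pyrrolidin-1-yl)ethyl chain of compound 3 stands apart. Nothing measured here accounts for this difference.

As far as these compounds go, it remains open whether the step goes with the ring or with the amine nitrogen, which a dimethylamino or primary amino group at the same place would help separate. A carboxylic acid or a longer chain would show how far the position's response extends, as three chain ends support no general trend.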